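This account rests on a few compounds, and the source may have more. Where it says the series, first, only, none or still open, it means among the compounds named here.

Measured compounds:
compound 1 `COc1ccc(F)cc1CNCCCNc1ccnc2cc(Cc3ccccc3)ccc12`, 9.47
compound 2 `COc1ccc(F)cc1CNCCCNc1ccnc2cc(-c3ccc(C(F)(F)F)cc3)ccc12`, 9.47
compound 3 `COc1cccc(CNCCCNc2ccnc3cc(-c4ccc(C(F)(F)F)cc4)ccc23)c1O`, 9.47

All three values come from a physicochemical assay for acid dissociation. Compound 2 and compound 1 differ in one place: benzyl in place of 4-(trifluoromethyl)phenyl on an aromatic carbon. The step between them is no change at the digits printed from compound 2 to compound 1 (within the scatter). Compound 2 and compound 3 differ in another place: 2-hydroxy-3-methoxyphenyl in place of 5-fluoro-2-methoxyphenyl on a saturated chain carbon bound to an amine nitrogen. That step is no change at the digits printed from compound 2 to compound 3 (within the scatter). Compound 3 therefore stands level with compound 1 and compound 2 in this assay, all three within the usual scatter of each other.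

Compound 4 `COc1cccc(CNCCCNc2ccnc3cc(Cc4ccccc4)ccc23)c1O` is not yet measured. It differs from compound 3 by benzyl in place of 4-(trifluoromethyl)phenyl on an aromatic carbon. Within the data shown here, this is the same change as the one from compound 2 to compound 1, made on a core that differs from that of compound 2 by 2-hydroxy-3-methoxyphenyl in place of 5-fluoro-2-methoxyphenyl on a saturated chain carbon bound to an amine nitrogen. Because no change at the digits printed from compound 2 to compound 1 (within the scatter), the expected step from compound 3 to compound 4 is no change at the digits printed from compound 3 to compound 4 (within the scatter), a step of the same size as the earlier one. Compound 4 is estimated at 9.47 in this assay, with a likely range from 9.2 to 9.75.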

Compound 4, acid dissociation constant: 9.47
Compound 4: middle estimate and measured number agree at the digits printed; measured number inside the range.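

In this assay, benzyl in place of 4-(trifluoromethyl)phenyl on an aromatic carbon gives no change at the digits printed from compound 3 to compound 4 (within the scatter) on the core of compound 3, the same outcome as no change at the digits printed from compound 2 to compound 1 (within the scatter) on the core of compound 2, and 2-hydroxy-3-methoxyphenyl in place of 5-fluoro-2-methoxyphenyl gives no change at the digits printed from compound 1 to compound 4 (within the scatter) on the core of compound 1. Among these compounds, the change therefore carries across these two cores with no step on either, so the four compounds close a square of level values in this read-out, but a step of no size is a weak test, and the square does not show that a step of real size would carry over, nor does one pair of cores make a rule for the series. No measurement shown here speaks to why the read-out stays level.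

Still open, on these data alone, is whether the level read-out holds with an amine or a carboxylic acid in place of benzyl on that aromatic carbon. Also open, as far as these compounds go, is whether a group other than these two substituted phenyl rings on the saturated chain carbon would leave this assay equally unmoved.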